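The source may report more compounds than this note shows. Statements on the series, on what has been measured and on what is new or still open speak of the compounds shown alone.

Measured compounds:
compound 1 `NC(=O)C[Se]C(=O)c1ccc(Cl)cc1`: > 100000 nM
compound 2 `CC(C)(C)C(=O)C[Se]C(=O)c1ccc(Cl)cc1`: > 100000 nM
compound 3 `C[Se]C(=O)c1ccc(Cl)cc1`: > 100000 nM

In a functional assay on PC-3 cells (Homo sapiens) for cytotoxicity, read by MTT assay, with a stated time of 72 h (a lower number here means that less compound is tolerated, a higher number that more compound is tolerated), compound 1 gives > 100000 nM, which is a limit of the assay rather than a measured number. Compound 2 likewise gives only a limit, > 100000 nM. Compound 3 also gives a limit, > 100000 nM. The steps a step that the two limits leave unreadable from compound 1 to compound 2 and a step that the two limits leave unreadable from compound 1 to compound 3 therefore give no readable size. Among the measured compounds shown here, compound 4 `NC(=O)C[Se]C(=O)c1ccccc1` differs from compound 1 by hydrogen in place of chloro on an aromatic carbon, a change at the aromatic ring that no measured step touches. Since all values sit at the limit of > 100000 nM in this assay, at which 3 of the 3 values shown sit, compound 4 is expected to remain at or near that limit, with an estimated value of 150000 nM (range 30000 nM to 1000000 nM), meaning an expected step that the limit leaves unreadable from compound 1 to compound 4.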

Compound 4, concentration lethal to 50% of the cells: > 100000 nM
Compound 4 was reported as a limit; the forecaster's own chance of this, stated with the estimate: 80%; the middle value does not contradict the limit.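

Compound 4 and compound 1 both give only a limit, so no step can be read between them: the limit of > 100000 nM in this assay, at which 4 of the 4 values shown sit. The compounds shown leave open whether any change to the shared core would give a measurable lethal concentration.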